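The compounds below may be only part of what the source reports. "The series", "measured", "known", "first", "only" and "open" are said of these compounds alone.

Compound 1 `O=C1/C(=C/c2ccc(Br)cc2)Cc2ccccc21` carries a bromo group on its outer aromatic ring. In a functional assay on P388 cells (Mus musculus) for inhibition (a lower number here means a stronger inhibitor, a higher number a weaker inhibitor), compound 1 gives only a limit, > 50000 nM, and no number (the limit of > 50000 nM in this assay, at which 1 of the 3 values shown sits). Compound 2 `Cc1ccc(/C=C2\Cc3ccccc3C2=O)cc1` arises from compound 1 through (methyl in place of bromo on an aromatic carbon); in this assay compound 2 gives 38600 nM, so the step of an at least 1.2-fold lower number from compound 1 to compound 2 (0.11 log units; that floor lies within the scatter) is small. Compound 3 `O=C1/C(=C/c2ccc(Br)cc2)CCc2ccccc21` has a different core; how the cores of compound 1 and compound 3 differ is not broken down here. In this assay compound 3 gives 20400 nM. Compound 4 `Cc1ccc(/C=C2\CCc3ccccc3C2=O)cc1` arises from compound 3 through the same change, (methyl in place of bromo on an aromatic carbon). Because the earlier step of an at least 1.2-fold lower number from compound 1 to compound 2 (0.11 log units; that floor lies within the scatter) stayed small, the step from compound 3 to compound 4 is expected to be of similar size, a 1.4-fold lower number from compound 3 to compound 4 (0.13 log units; within the scatter). Compound 4 is therefore expected to give about 15000 nM.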

Compound 4, half-maximal inhibitory concentration: 17700 nM
The estimate for compound 4 lay 1.2-fold (0.07 log units) below the measured number; the measured number falls inside the stated range.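

In this assay, methyl in place of bromo gives a 1.2-fold lower number from compound 3 to compound 4 (0.06 log units; within the scatter), so on the core of compound 3 this change leaves the number within the scatter. This does not show that the change carries over equally from one core to the other, as only a floor is known for the step on the core of compound 1: the same change on two cores in this assay, an at least 1.2-fold lower number (0.11 log units; that floor lies within the scatter) from compound 1 to compound 2 and a 1.2-fold lower number (0.06 log units; within the scatter) from compound 3 to compound 4; the limit leaves it open whether they differ. Going by these compounds, compound 1 gives only a limit, > 50000 nM, so the true size of that first step remains unknown.

The compounds shown carry only bromo or methyl at this place, so the effect of an amine, a carboxylic acid or a longer chain there remains open. On these data alone, whether the step stays this small on any further core is also open.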